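This account rests on a few compounds, and the source may have more. Where it says the series, first, only, none or still open, it means among the compounds named here.

Measured compounds:
- compound 1, `CCCCNc1nc(N)nc(C)c1CCCC`: 780 nM
- compound 2, `CCCC#Cc1c(C)nc(N)nc1NCCCC`: 5000 nM
- compound 3, `C#Cc1c(C)nc(N)nc1NCCCC`: 4900 nM

Compound 1 gives the lowest number of the three in an assay on HEK293 cells for agonist activity at Toll-like receptor 8 (Homo sapiens), read by spectrophotometry; a higher number here means that more compound is needed for the effect, a lower number that less compound is needed. Both changes to the butyl chain on the aromatic carbon moved the number upward: a 6.4-fold higher number from compound 1 to compound 2 (0.81 log units; beyond the scatter) and a 6.3-fold higher number from compound 1 to compound 3 (0.80 log units; beyond the scatter). Between the two alkynes the length of the chain beyond the triple bond made no difference, a 1.0-fold lower number from compound 2 to compound 3 (0.01 log units; within the scatter).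

Compound 4, `CCCCNc1nc(N)nc(C)c1CCCn1cncn1`, keeps the butyl chain saturated and alters only its end: 1H-1,2,4-triazol-1-yl in place of methyl on a saturated chain carbon, three bonds along the chain from an aromatic carbon. Within the data shown here, no measured pair shows a ring of this kind entering the chain, so the measured steps bear on it only loosely, in that every alteration of this chain so far has raised the number beyond the scatter. The change in compound 4 is larger in heavy atoms and acceptors than either alkyne change, but the chain stays saturated as in compound 1. A rise beyond the scatter is expected, of a size near the alkyne steps, a 3.2-fold higher number from compound 1 to compound 4 (0.51 log units; beyond the scatter). The number for compound 4 is therefore estimated at 2500 nM, with a range of 600 nM to 10000 nM.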

Compound 4, half-maximal effective concentration: 1050 nM
Compound 4: the middle estimate sits 2.4-fold (0.38 log units) above what was measured, within the range that was stated.
By their numbers in this assay, from the lowest: compounds 1 and 4 (each within the scatter of the next); then compounds 3 and 2 (each within the scatter of the next).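

In this assay, a five-membered aromatic ring at the end of the saturated chain, on a saturated chain carbon three bonds along the chain from an aromatic carbon, gives a 1.3-fold higher number from compound 1 to compound 4 (0.13 log units; within the scatter), so this chain is the first shown to take a change without leaving the scatter of compound 1. The alkyne changes at the aromatic carbon gave a 6.4-fold higher number from compound 1 to compound 2 (0.81 log units; beyond the scatter) and a 6.3-fold higher number from compound 1 to compound 3 (0.80 log units; beyond the scatter), so alteration of this chain does not by itself carry a penalty, although compound 4 is a single example at the chain end. Nothing available explains the result for the ring.

Still open, as far as these compounds go, is whether an amine or a carboxylic acid at the same chain end stays within the scatter of compound 1. Also open, from the compounds shown here alone, is whether a longer chain carrying 1H-1,2,4-triazol-1-yl does the same.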